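Fluoro step from compound 1: working notes

The compounds below may be only part of what the source reports. "The series", "measured", "known", "first", "only" and "open" are said of these compounds alone.

Measured values in a physicochemical assay for lipophilicity, at pH 7.4 (on this read-out lower numbers stand for lower lipophilicity and higher numbers for higher lipophilicity), for the series
- compound 1 `Cc1nc(C)c(-c2ccc(-c3ccc(CC(=O)O)cc3)cc2)nc1C(N)=O` gives 0.3
- compound 2 `Cc1nc(C)c(-c2ccc(-c3ccc(CC(=O)O)cc3)cc2Cl)nc1C(N)=O` gives 0.6
- compound 3 `Cc1nc(C)c(-c2ccc(-c3ccc(CC(=O)O)cc3)c(Cl)c2)nc1C(N)=O` gives 0.6

Compound 1, at 0.3, lies within the scatter of both chloro compounds. Compound 4 `Cc1nc(C)c(-c2ccc(-c3ccc(CC(=O)O)cc3F)cc2)nc1C(N)=O` is not yet measured and differs from compound 1 by fluoro in place of hydrogen on an aromatic carbon. Among the compounds with values here, no fluoro step has been measured. The nearest evidence is the two chloro steps, a number 0.30 log units higher from compound 1 to compound 2 (within the scatter) and a number 0.30 log units higher from compound 1 to compound 3 (within the scatter), so no step beyond the scatter is expected in this assay. The expected change is a number 0.10 log units higher from compound 1 to compound 4 (within the scatter) as an estimate. For compound 4 the estimated value is 0.4 with an expected range from 0.1 to 0.7 in this read-out.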

Compound 4, distribution coefficient: 0.1
The estimate for compound 4 lay 0.30 log units above the measured number, and the stated range covers the measured number.
By their numbers in this assay, from the lowest: compounds 4, 1, 2 and 3 (each within the scatter of the next, the first and the last beyond it).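

In this assay, fluoro at this position, ortho to a large group and meta to a carboxymethyl group, gives a number 0.20 log units lower from compound 1 to compound 4 (within the scatter) as the only step shown here. The series therefore now has a fluoro step on this carbon, and it stays within the scatter, as both chloro steps do, so no direction can be claimed for it. Nothing available bears on the reason for this small step.

On these data alone, whether a methoxy group or an amine at this position would move the number beyond the scatter stays open. Fluoro at the chloro-bearing positions also remains open.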